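A new group on the same oxygen

This account rests on a few compounds, and the source may have more. Where it says the series, first, only, none or still open, it means among the compounds named here.

Within the data shown here, in a functional assay on HeLa cells (Homo sapiens) for cytotoxicity (a lower number here means a stronger inhibitor, a higher number a weaker inhibitor), compound 2 (`CS(=O)(=O)OC1=CC(=O)c2ccccc2C1=O`) gives 7610 nM, the lower of the two numbers so far, while compound 1 (`C/C=C/C(=O)OC1=CC(=O)c2ccccc2C1=O`) gives 37900 nM. Compound 3 (`O=C1C=C(Oc2cccs2)C(=O)c2ccccc21`) has thiophen-2-yl in place of methylsulfonyl on that same oxygen: thiophen-2-yl in place of methylsulfonyl on an oxygen on an unsaturated carbon. Among the measured compounds shown here, only one measured step bears on this, a 5.0-fold lower number from compound 1 to compound 2 (0.70 log units; beyond the scatter), a modest change at the same place but between other groups. It suggests a size, not a direction, though a rise from the lower number seems somewhat likelier. The expected change is a 1.4-fold higher number from compound 2 to compound 3 (0.16 log units; within the scatter). For compound 3 the estimated value is 11000 nM, with a range from 3500 nM to 35000 nM.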

Compound 3, half-maximal inhibitory concentration: 35300 nM
Estimate against measurement, compound 3: 3.2-fold (0.51 log units) below, and the stated range ends below it.
By their numbers in this assay, from the lowest: compound 2; then compounds 3 and 1 (each within the scatter of the next).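

Methylsulfonyl now stands alone on this oxygen in this assay: replacing it with the thiophen-2-yl ring gives a 4.6-fold higher number from compound 2 to compound 3 (0.67 log units; beyond the scatter), which removes the gain seen earlier. Compared with the (prop-1-en-1-yl)carbonyl group, thiophen-2-yl shows a 1.1-fold lower number from compound 1 to compound 3 (0.03 log units; within the scatter), so these two quite different groups cannot be told apart here. Nothing available explains the difference.

The compounds shown leave open whether the lower number depends on the sulfonyl unit or on its small methyl end. A longer chain on the sulfonyl, such as ethylsulfonyl, or a phenylsulfonyl group would address this.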